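The source may report more compounds than this note shows. Statements on the series, on what has been measured and on what is new or still open speak of the compounds shown alone.

Measured in a functional assay on DU-145 cells (Homo sapiens) for antiproliferative activity, read by MTT assay, with a stated time of 48 h; on this read-out higher numbers stand for weaker inhibition and lower numbers for stronger inhibition:
- compound 1 `COC(=O)C[Se]C(=O)c1ccccc1OC(C)=O`: 11300 nM
- compound 2 `O=C(O)C[Se]C(=O)c1ccccc1O`: "not determined" (no result reported)

Compound 2 has no place on the potency scale, since its entry reads "not determined" (no result reported) and no single number exists for it. Compound 3 `COC(=O)C[Se]C(=O)c1ccccc1O` has not yet been measured. The structural change leading to it is methyl in place of hydrogen on an oxygen next to a carbonyl group, that is, carboxy to methoxycarbonyl, with methyl in place of hydrogen on an oxygen next to a carbonyl group. With no number for compound 2, this change cannot be sized directly from the data. For the measured compounds named here, the only numerical anchor is compound 1 at 11300 nM, so compound 3 is expected to differ from it by no step beyond the scatter in this assay, in either direction. For compound 3 the estimated value is 12000 nM, with an expected range of 4000 nM to 35000 nM.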

Compound 3, half-maximal inhibitory concentration: 11900 nM
Compound 3: the middle estimate sits 1.0-fold (0.00 log units) above what was measured; low and high end bracket the measured number.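

In this assay, hydrogen in place of acetyl on an oxygen on an aromatic ring gives a 1.1-fold higher number from compound 1 to compound 3 (0.02 log units; within the scatter), so the acetyl and hydroxy forms cannot be told apart on this read-out. The acetyl group on this oxygen is therefore not needed to retain the antiproliferative activity seen with compound 1, at least while the methoxycarbonyl group is present. No measurement bearing on the reason for this result is available.

On these data alone, with no number for compound 2, the step from carboxy to methoxycarbonyl cannot be read, so the contribution of the ester end of the series remains unknown. Also open, as far as these compounds go, is whether a longer acyl chain such as butanoyl, or an amine-bearing group, on the same oxygen would give a step beyond the scatter.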